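Removing the isopropylcarbamoyl cap from compound 3

A few compounds are considered here, and "the series" means these few. Any claim that something is new, unique, unknown or untested is made for them only; others in the source may bear on it.

Compound 3 `CC(C)NC(=O)NCCS(=O)(=O)NC(=O)c1ccc(Nc2nc(NC3(c4ccc(Cl)cc4)CC3)nc(OCC(F)(F)F)n2)cc1` gives 45 nm/s in a physicochemical assay for permeability, using PAMPA, at pH 7.4 (on this read-out lower numbers stand for lower permeability and higher numbers for higher permeability), level with compound 1 `CC(C)NCCS(=O)(=O)NC(=O)c1ccc(Nc2nc(NC3(c4ccc(Cl)cc4)CC3)nc(OCC(F)(F)F)n2)cc1` at 45 nm/s and nearest to it, while compound 2 `CC(C)(C)NC(=O)NCCS(=O)(=O)NC(=O)c1ccc(Nc2nc(NC3(c4ccc(Cl)cc4)CC3)nc(OCC(F)(F)F)n2)cc1` at 49 nm/s stands furthest from it. The change to compound 4 `NCCS(=O)(=O)NC(=O)c1ccc(Nc2nc(NC3(c4ccc(Cl)cc4)CC3)nc(OCC(F)(F)F)n2)cc1` is hydrogen in place of isopropylcarbamoyl on an amine nitrogen. The measured steps that touch this nitrogen are no change at the digits printed from compound 1 to compound 3 (within the scatter) and a 1.1-fold lower number from compound 2 to compound 3 (0.04 log units; within the scatter), so on the shown data its substituent has not moved this assay. Compound 4 carries a bare amine, a case none of the three measured compounds shows, and its number is expected to stay near compound 3, with the step of a 1.5-fold lower number from compound 3 to compound 4 (0.18 log units; within the scatter) as the estimate. Compound 4 is therefore estimated at 30 nm/s, within a range from 10 nm/s to 70 nm/s.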

Compound 4, apparent permeability: 153 nm/s
Beside the measured number, compound 4's estimate is 5.1-fold (0.71 log units) below it; the measured number lies above the stated range.
By their numbers in this assay, from the lowest: compounds 1, 3 and 2 (each within the scatter of the next); then compound 4.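

In this assay this amine nitrogen turns out to matter: the three substituted compounds lay within the scatter of one another, yet hydrogen in place of the substituent gives a 3.4-fold higher number from compound 1 to compound 4 (0.53 log units; beyond the scatter) and a 3.1-fold higher number from compound 2 to compound 4 (0.49 log units; beyond the scatter) and a 3.4-fold higher number from compound 3 to compound 4 (0.53 log units; beyond the scatter) with all three steps beyond the scatter. Isopropyl, isopropylcarbamoyl and (tert-butyl)carbamoyl thus read alike here, and only the bare amine of compound 4 stands apart. Nothing measured here offers a reason for this step.

The compounds shown leave open whether a single methyl or an acetyl on this nitrogen would stay with compound 4 or with the other three. They also leave open whether a longer chain than 2-aminoethyl carrying the same bare amine would do so.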